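This account rests on a few compounds, and the source may have more. Where it says the series, first, only, none or still open, it means among the compounds named here.

Compound 1 `CCn1c(=O)c2nc(-c3cnn(Cc4cccc(F)c4)c3)[nH]c2n(CC)c1=O` gives 380 nM in an assay on CHO cells for displacement of a labelled ligand from adenosine receptor A1 (Homo sapiens); on this read-out higher numbers stand for weaker inhibition and lower numbers for stronger inhibition.
Compound 2 `CCCn1c(=O)c2nc(-c3cnn(Cc4cccc(C)c4)c3)[nH]c2n(CCC)c1=O` gives 48 nM in this assay.
Compound 3 `CCCn1c(=O)c2nc(-c3cnn(Cc4cc(C(F)(F)F)cc(Cl)c4F)c3)[nH]c2n(CCC)c1=O` gives "not determined" (no result reported) in this assay, that is, no result is reported for it.

Among the two numbers shown, compound 2 stands lowest, and compound 1 sits at a higher number that lies beyond the usual scatter of repeated measurements. Compound 4 `CCCn1c(=O)c2nc(-c3cnn(Cc4cc(Cl)ccc4Cl)c3)[nH]c2n(CCC)c1=O` has not yet been measured in this assay. It differs from compound 2 in one place: 2,5-dichlorophenyl in place of 3-methylphenyl on a saturated chain carbon bound to an aromatic nitrogen. Within the data shown here, no measured pair shows this exact change, so its effect is unknown. The step of a 1.3-fold higher number from compound 2 to compound 4 (0.10 log units; within the scatter) that I expect is small, in no clear direction, and not beyond the scatter. For compound 4 I therefore estimate 60 nM in this assay, with a range from 15 nM to 250 nM.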

Compound 4, inhibition constant: 190 nM
Beside the measured number, compound 4's estimate is 3.2-fold (0.50 log units) below it, within the range that was stated.
By their numbers in this assay, from the lowest: compound 2; then compounds 4 and 1 (each within the scatter of the next).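

Putting 2,5-dichlorophenyl in place of 3-methylphenyl on a saturated chain carbon bound to an aromatic nitrogen gives a 4.0-fold higher number from compound 2 to compound 4 (0.60 log units; beyond the scatter) in this assay. Among these compounds, this is the first pair differing in one place, and it shows that inhibition at this position changes with the phenyl substituents, here weakening with this swap. Nothing measured here explains the shift.

The compounds shown leave open whether a single chlorine would give a similar step, and how an amine or a carboxylic acid on this phenyl ring would read.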